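This account rests on a few compounds, and the source may have more. Where it says the series, first, only, none or still open, it means among the compounds named here.

Compound 1 `Cc1cccc(Nc2ncnc3ccc(NC(=S)NCc4ccccc4)cc23)c1C` and compound 2 `Oc1cccc(Nc2ncnc3ccc(NC(=S)NCc4ccccc4)cc23)c1` share one core and differ only in the aromatic group on a nitrogen. In a functional assay on MDA-MB-231 cells (Homo sapiens) for inhibition, read by MTT assay, with a stated time of 48 h (on this read-out lower numbers stand for stronger inhibition of growth and higher numbers for weaker inhibition of growth), compound 1 gives 28700 nM. Compound 2 gives > 30000 nM, which is a limit of the assay and not a number. On these data alone, compound 2 therefore sits at the limit of > 30000 nM in this assay, at which 1 of the 2 values shown sits, so its true value remains unknown.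

The next change is made at the same place, leading to compound 3 `NS(=O)(=O)c1ccc(Nc2ncnc3ccc(NC(=S)NCc4ccccc4)cc23)cc1`: 4-sulfamoylphenyl in place of 3-hydroxyphenyl on a nitrogen on an aromatic ring. In words, this puts 4-sulfamoylphenyl in place of 3-hydroxyphenyl on a nitrogen on an aromatic ring.

For the measured compounds named here, only one measured step bears on this change. It is an at least 1.0-fold higher number from compound 1 to compound 2 (0.01 log units; that floor lies within the scatter), which puts 3-hydroxyphenyl in place of 2,3-dimethylphenyl at that same nitrogen. This step gives only a floor, and it offers no ground for expecting a large move in either direction. The expected change is a number no higher from compound 2 to compound 3 (the limit leaves the size open), which means no step beyond the scatter is anticipated. For compound 3 the estimated value is 30000 nM, with an expected range from 12000 nM to 70000 nM.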

Compound 3, concentration for 50% growth inhibition: > 30000 nM
Compound 3 gave a limit, no number; the forecaster's own chance of this, stated with the estimate: 55%; the middle value sits exactly at the limit.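

Compound 3 also reads as a limit and not a number in this assay, so two different groups on a nitrogen on an aromatic ring, 3-hydroxyphenyl and 4-sulfamoylphenyl, now end at the same limit: the limit of > 30000 nM in this assay, at which 2 of the 3 values shown sit. On these data alone, the comparison with the dimethylated compound gives an at least 1.0-fold higher number from compound 1 to compound 3 (0.01 log units; that floor lies within the scatter), which is only a floor, so the true size of this change remains unknown. The step between the two limits cannot be read, so these results do not place either group ahead of the other.

As far as these compounds go, whether compound 2 and compound 3 truly differ remains open, since neither has a measured number. Also open, from the compounds shown here alone, is whether a phenyl group carrying an amine or a carboxylic acid at this place would give a clearly lower number than compound 1 at 28700 nM.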